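The compounds below may be only part of what the source reports. "The series", "measured", "known", "first", "only" and "open" are said of these compounds alone.

Of the compounds shown here, three of a shared core have been tested so far. Compound 1 `COc1cccc(/C=C2\CCC/C(=C\c3ccc(Cl)c(Cl)c3)C2=O)c1OC`, compound 2 `COc1cccc(/C=C2\CCC/C(=C\c3cc(OC)c(OC)c(OC)c3)C2=O)c1OC` and compound 3 `COc1ccc(/C=C2\CCC/C(=C\c3ccc(Cl)cc3)C2=O)cc1OC` were each measured in an ADME assay on NHDF cells (Homo sapiens) for cytotoxicity, read by MTT assay, with a stated time of 72 h; on this read-out higher numbers stand for weaker inhibition and lower numbers for stronger inhibition. In this assay compound 1 gives 25500 nM, compound 2 gives 7900 nM and compound 3 gives 11200 nM. Among these three numbers compound 3 holds the second highest; its nearest neighbour is compound 2, whose number lies within the scatter of repeated measurements, while the gap to compound 1 lies beyond the scatter, with compound 1 the higher of the two.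

The next compound, compound 4 `COc1ccc(/C=C2\CCC/C(=C\c3ccc(Cl)c(Cl)c3)C2=O)cc1OC`, has not yet been measured in this assay. It comes from compound 3 through one change: chloro in place of hydrogen on an aromatic carbon. Put one bond further out, the change reads 4-chlorophenyl to 3,4-dichlorophenyl; the new chloro group sits ortho to a chloro group and meta to a large group.

Within the data shown here, no pair of measured compounds differs in one place only, so no measured step can guide this one directly. Still, a small step is expected, and for compound 4 the step from compound 3 is estimated as a 1.3-fold higher number from compound 3 to compound 4 (0.13 log units; within the scatter), which need not lie beyond the scatter. The value expected for compound 4 is 15000 nM, with a range from 6000 nM to 40000 nM.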

Compound 4, half-maximal inhibitory concentration: 10100 nM
The estimate for compound 4 lay 1.5-fold (0.17 log units) above the measured number; the measured number falls inside the stated range.
By their numbers in this assay, from the lowest: compounds 2, 4 and 3 (each within the scatter of the next); then compound 1.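

In this assay the change from 4-chlorophenyl to 3,4-dichlorophenyl is a 1.1-fold lower number from compound 3 to compound 4 (0.04 log units; within the scatter) and so gives no readable difference in cytotoxicity on these cells. Among these compounds, this is the first pair in the set that differs in one place only, which makes it the first direct look at this position: on an aromatic carbon, ortho to a chloro group and meta to a large group, chloro and hydrogen cannot be told apart on this read-out, at least with the rest of compound 3 held fixed. No measurement at hand offers an explanation for this flat result.

On these data alone, whether a group of a different kind on this same carbon, such as an amine or a carboxylic acid, would also leave the number within the scatter remains open. A single pair also cannot tell whether the same chloro change would read the same way with the methoxy groups on the other aromatic ring placed as they are in compound 1.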